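Isopropyl to Butyl on an Aromatic Nitrogen

A few compounds are considered here, and "the series" means these few. Any claim that something is new, unique, unknown or untested is made for them only; others in the source may bear on it.

Compound 1 `CC(C)n1ncnc1-c1ccccc1NCC1=NCCN1` is the starting point here. For the measured compounds named here, in an in vitro functional assay on cells (Fibroblast) for agonist activity at Alpha-1D adrenergic receptor (Homo sapiens) (a higher number here means that more compound is needed for the effect, a lower number that less compound is needed), compound 1 gives 3160 nM, and this is the only outright number among the two values shown. Compound 2 `Cc1nc(-c2ccccc2NCC2=NCCN2)n(C)n1` gives < 5020 nM in this assay, which is a limit of the assay rather than a measured number; one of the two values therefore sits at the limit of < 5020 nM in this assay, at which 1 of the 2 values shown sits.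

Compound 3 `CCCCn1ncnc1-c1ccccc1NCC1=NCCN1` has not yet been measured in this assay. It differs from compound 1 in one place: butyl in place of isopropyl on an aromatic nitrogen. Going by the values given here, no step between two measured compounds is available, so there is nothing to compare this change against, and the expectation rests on compound 1 alone. For compound 3 the step of a 1.1-fold lower number from compound 1 to compound 3 (0.02 log units; within the scatter) from compound 1 is expected to stay within the usual scatter, in no particular direction. Compound 3 is accordingly estimated at 3000 nM, with a range from 1000 nM to 10000 nM.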

Compound 3, half-maximal effective concentration: 398 nM
For compound 3 the middle estimate is 7.5-fold (0.88 log units) above the measured one; the measured number lies below the stated range.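

In this assay putting butyl in place of isopropyl on an aromatic nitrogen gives a 7.9-fold lower number from compound 1 to compound 3 (0.90 log units; beyond the scatter) and so shows that this position responds to the group it carries. The change is small on paper, 4 heavy atoms in place of 3, with no ring, hydrogen-bond donor, hydrogen-bond acceptor or net charge on either group, yet the step lies beyond the usual scatter. Nothing measured here bears on why this change has such an effect.

Going by these compounds, with only isopropyl and butyl to compare at this position, it remains open whether the number would keep falling with a longer chain such as pentyl or hexyl. On these data alone, it is also open whether a branched tert-butyl or a butyl chain ending in an amine or a carboxylic acid would behave like butyl.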